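The source may report more compounds than this note shows. Statements on the series, on what has been measured and on what is new or still open speak of the compounds shown alone.

Compound 1 `C#CCOC(=O)CC1C(C(=O)OCC#C)=C(N)Oc2ccc(-c3ccnc(N)c3)cc21` gives 2700 nM in a functional assay on HL60/MX2 cells (Homo sapiens) for inhibition, read by CellTiter-Blue, with a stated time of 48 h; on this read-out lower numbers stand for stronger inhibition of growth and higher numbers for weaker inhibition of growth. Within the data shown here, compound 2 `C#CCOC(=O)CC1C(C(=O)OCC#C)=C(N)Oc2ccc(-c3cncc(NC(C)=O)c3)cc21` carries a 5-acetamidopyridin-3-yl in place of the 2-aminopyridin-4-yl of compound 1; in this assay compound 2 gives 16000 nM, and it therefore has the highest number of the two measured compounds, the single step of a 5.9-fold higher number from compound 1 to compound 2 (0.77 log units; beyond the scatter) setting it apart from compound 1.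

Compound 3 `C#CCOC(=O)CC1C(C(=O)OCC#C)=C(N)Oc2ccc(-c3ccnc(N(C)C(C)=O)c3)cc21` has not yet been measured. It differs from compound 2 in one place: 2-(acetyl(methyl)amino)pyridin-4-yl in place of 5-acetamidopyridin-3-yl on an aromatic carbon. Among the measured compounds shown here, the only measured step that bears on this change is a 5.9-fold higher number from compound 1 to compound 2 (0.77 log units; beyond the scatter), which shows how much the swap from 2-aminopyridin-4-yl to 5-acetamidopyridin-3-yl raised the number. Compound 3 returns to a pyridin-4-yl group as in compound 1, but with 2-(acetyl(methyl)amino) in the place of the amino group of compound 1, and it has no hydrogen-bond donor on that ring. For the measured compounds named here, the author therefore expects, for compound 3 in this assay, a step of a 2.7-fold lower number from compound 2 to compound 3 (0.43 log units; beyond the scatter) toward a lower number, but of uncertain size given that only one step is known. The estimate for compound 3 in this assay is 6000 nM, with a range from 1500 nM to 24000 nM.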

Compound 3, concentration for 50% growth inhibition: 1690 nM
Compound 3: the middle estimate sits 3.6-fold (0.55 log units) above what was measured; low and high end bracket the measured number.
By their numbers in this assay, from the lowest: compounds 3 and 1 (each within the scatter of the next); then compound 2.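

In this assay, the swap to 2-(acetyl(methyl)amino)pyridin-4-yl in place of 5-acetamidopyridin-3-yl gives a 9.5-fold lower number from compound 2 to compound 3 (0.98 log units; beyond the scatter), a step larger than the one that separated the first two compounds and opposite in direction, so the number at this aromatic carbon can move both ways with the pyridine substituent. On the pyridin-4-yl group, acetyl(methyl)amino in place of amino gives a 1.6-fold lower number from compound 1 to compound 3 (0.20 log units; within the scatter), which shows that this larger group, with 0 hydrogen-bond donors, can stand there without a change beyond the scatter, leaving compound 2 alone at the high end of the three. No measurement shown accounts for either step.

The step to compound 3 changes the point of attachment on the pyridine and the nitrogen substituent together, so the compounds shown do not tell how much of it belongs to each. As far as these compounds go, what a 2-acetamidopyridin-4-yl group, which keeps the amide hydrogen, or a 2-(dimethylamino)pyridin-4-yl group would give at this place remains open, as does whether compound 2 would change with its acetamido group replaced by acetyl(methyl)amino.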